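Aryl amine variation on the silyl-protected scaffold

The source may hold more compounds than are shown below. What is called first, only, known or untested is meant among the compounds shown, and "the series" means these compounds.

Compound 1 `C=C1[C@@H](OC(C)=O)C[C@@H]2[C@](C)(CO[Si](C)(C)C(C)(C)C)[C@H](OC(C)=O)CC[C@@]2(C)[C@@H]1C[C@@H](Nc1ccc(F)cc1)C1=CCOC1=O` stands lowest of the three numbers in hand: in a functional assay on A549 cells (Homo sapiens) for cytotoxicity, read by sulforhodamine B assay (a lower number here means a stronger inhibitor, a higher number a weaker inhibitor), compound 1 gives 4550 nM. Compound 3 `C=C1[C@@H](OC(C)=O)C[C@@H]2[C@](C)(COC=O)[C@H](OC(C)=O)CC[C@@]2(C)[C@@H]1C[C@@H](Nc1ccc(F)cc1)C1=CCOC1=O` gives 21300 nM in this assay, and compound 2 `C=C1[C@@H](OC(C)=O)C[C@@H]2[C@](C)(COC=O)[C@H](OC(C)=O)CC[C@@]2(C)[C@@H]1C[C@@H](Nc1ccccc1C(=O)O)C1=CCOC1=O` gives 45900 nM. Of the two single-point steps, a 4.7-fold higher number from compound 1 to compound 3 (0.67 log units; beyond the scatter) concerns the group on the oxygen on the saturated carbon and leaves the amine untouched. Going by the values given here, the step of a 2.2-fold lower number from compound 2 to compound 3 (0.33 log units; beyond the scatter) is the only measured change at the amine nitrogen, and it is modest in size.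

Compound 4 `C=C1[C@@H](OC(C)=O)C[C@@H]2[C@](C)(CO[Si](C)(C)C(C)(C)C)[C@H](OC(C)=O)CC[C@@]2(C)[C@@H]1C[C@@H](Nc1cccc2ccccc12)C1=CCOC1=O` differs from compound 1 at that same amine nitrogen: naphthalen-1-yl in place of 4-fluorophenyl on an amine nitrogen. Among the compounds with values here, no measured compound carries naphthalen-1-yl, so the direction of this step is not fixed by the data. Within the data shown here, the single aryl exchange at the amine nitrogen, from compound 2 to compound 3, moved the number only modestly, and the silyl group of compound 1 is retained in compound 4, so a step of at most modest size is anticipated, in either direction, and quite possibly none beyond the scatter.

Compound 4 is expected to give 4500 nM, with a range from 1500 nM to 14000 nM. For compound 4 the expected step is a 1.0-fold lower number from compound 1 to compound 4 (0.00 log units; within the scatter).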

Compound 4, half-maximal inhibitory concentration: 4970 nM
Beside the measured number, compound 4's estimate is 1.1-fold (0.04 log units) below it, and the stated range covers the measured number.
By their numbers in this assay, from the lowest: compounds 1 and 4 (each within the scatter of the next); then compound 3; then compound 2.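

At the amine nitrogen of the silyl-bearing compounds, the exchange in this assay reads a 1.1-fold higher number from compound 1 to compound 4 (0.04 log units; within the scatter) and so shows that naphthalen-1-yl can replace 4-fluorophenyl without moving the number, although the entering group has a second six-membered aromatic ring and no fluorine. Before this pair, the only aryl exchange at this nitrogen was a 2.2-fold lower number from compound 2 to compound 3 (0.33 log units; beyond the scatter) on compounds without the silyl group, so compound 4 gives the first reading of this position with the silyl group in place, and two different aryl groups there stand within the scatter of each other. No measurement in hand accounts for this match between the two aryl groups.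

Still open, from the compounds shown here alone, is whether 2-carboxyphenyl, which has been seen only without the silyl group, would stay level with compounds 1 and 4 once that group is present, and whether the match between 4-fluorophenyl and naphthalen-1-yl holds when the silyl group is absent. Also open, going by these compounds, is how the number responds when the amine nitrogen carries a pyridine ring, a cyclohexyl group or a longer alkyl chain in place of these carbon-only aromatic rings.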